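The source may hold more compounds than are shown below. What is called first, only, known or untested is meant among the compounds shown, and "the series" means these compounds.

Measured so far: compound 1 `O=C(/C=C/c1ccccc1)Nc1ccc2ncnc(Nc3cccc(Br)c3)c2c1` with 3.96 ug/mL in a functional assay on A549 cells (Homo sapiens) for antiproliferative activity, read by MTT assay, with a stated time of 48 h (a higher number here means a weaker inhibitor, a lower number a stronger inhibitor), and compound 2 `O=C(/C=C/c1ccc(Cl)cc1)Nc1ccc2ncnc(Nc3cccc(Cl)c3)c2c1` with 12.4 ug/mL in this assay.

Compound 2 gives the higher of the two numbers, and compound 1 the lower, the two values lying apart by more than the usual scatter of this assay. Within the data shown here, no single step between measured compounds is available here, since compound 1 and compound 2 differ in two places, so the difference between them cannot be assigned to either change.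

Compound 3 `COc1cccc(/C=C/C(=O)Nc2ccc3ncnc(Nc4cccc(Cl)c4)c3c2)c1` is built from compound 2 by one change: 3-methoxyphenyl in place of 4-chlorophenyl on a double-bonded chain carbon bound to a double-bonded chain carbon. Among the measured compounds shown here, nothing measured so far tells how this assay responds to such a change, and the cinnamamide portion has only been varied together with the halogen on the aniline. The expectation for compound 3 is therefore anchored on compound 2, with a step of a 1.2-fold lower number from compound 2 to compound 3 (0.09 log units; within the scatter) expected to fall within the scatter, in no particular direction. Compound 3 is thus estimated at 10 ug/mL, with a range from 4 ug/mL to 25 ug/mL.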

Compound 3, half-maximal inhibitory concentration: 2.58 ug/mL
Estimate against measurement, compound 3: 3.9-fold (0.59 log units) above; measured number outside the range, below it.
By their numbers in this assay, from the lowest: compounds 3 and 1 (each within the scatter of the next); then compound 2.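

In this assay, among these compounds, with the rest of the molecule unchanged, 3-methoxyphenyl in place of 4-chlorophenyl on a double-bonded chain carbon bound to a double-bonded chain carbon gives a 4.8-fold lower number from compound 2 to compound 3 (0.68 log units; beyond the scatter) as the first step that can be read at a single place. It shows that this assay is sensitive to the group at this position, which the earlier pair could not show, since compound 1 and compound 2 differ in two places at once. The change removes a chlorine and brings in an oxygen with one hydrogen-bond acceptor, and no measurement available here accounts for the size of the step.

The compounds shown leave open whether the step follows the loss of the chlorine, the arrival of the methoxy group, or the two together, as one swap cannot separate these. They also leave open how the position would respond to a hydroxyl group, an amine or a carboxylic acid on that ring, and whether the same step would hold with the bromine found in compound 1 on the other side of the shared core.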